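The source may report more compounds than this note shows. Statements on the series, on what has been measured and on what is new or still open speak of the compounds shown alone.

Measured so far in a functional assay on A549 cells (Homo sapiens) for cytotoxicity, read by MTT assay, with a stated time of 72 h; on this read-out higher numbers stand for weaker inhibition and lower numbers for stronger inhibition:
- Compound 1 `CNC(=O)c1cc(Oc2ccc(C(=O)/C=C/c3ccco3)cc2)ccn1`: "not determined" (no result reported)
- Compound 2 `CNC(=O)c1cc(Oc2ccc(C(=O)/C=C/c3ccc(Cl)c(Cl)c3)cc2)ccn1`: 33700 nM
- Compound 3 `CNC(=O)c1cc(Oc2ccc(C(=O)/C=C/c3ccc(OC)c(OC)c3OC)cc2)ccn1`: "not determined" (no result reported)

For the measured compounds named here, compound 2 holds the only number in this small set, so it cannot be ranked: compound 1 and compound 3 offer no result to compare it with. Compound 4 `CNC(=O)c1cc(Oc2ccc(C(=O)/C=C/c3ccc([N+](=O)[O-])cc3)cc2)ccn1` has yet to be measured. It keeps the core of compound 2 and exchanges one group: 4-nitrophenyl in place of 3,4-dichlorophenyl on a double-bonded chain carbon bound to a double-bonded chain carbon. Put plainly, 4-nitrophenyl stands in place of 3,4-dichlorophenyl on a double-bonded chain carbon bound to a double-bonded chain carbon.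

Going by the values given here, no measured pair shows what a swap at this place does, so the data give no size of step to lean on. In this assay, among the compounds with values here, the expectation is therefore no step beyond the usual scatter, in either direction, and the only guide is compound 2 at 33700 nM. The estimated change is a 1.1-fold lower number from compound 2 to compound 4 (0.05 log units; within the scatter). For compound 4 the expected value is 30000 nM, with an estimated range from 10000 nM to 80000 nM.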

Compound 4, half-maximal inhibitory concentration: > 50000 nM
Compound 4 gave a limit, no number (the forecaster's own chance of this, stated with the estimate: 15%); at least 1.6-fold (0.22 log units) between middle value and limit.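

In this assay the result for compound 4 is a limit and not a number: the limit of > 50000 nM in this assay, at which 1 of the 4 values shown sits.

For the compounds shown here, with 4-nitrophenyl in place of 3,4-dichlorophenyl on a double-bonded chain carbon bound to a double-bonded chain carbon, the data give an at least 1.4-fold higher number from compound 2 to compound 4 (0.17 log units; that floor lies within the scatter), the first step that can be read at this place. It shows that this swap brought no drop in the number, which is the direction that would mean stronger inhibition; whether the number truly rose, and by how much, stays unsettled, as the floor of the step does not clear the scatter.

Steps to compound 1 and compound 3 cannot be read, as neither carries a number. Still open, as far as these compounds go, is how an amine or a carboxylic acid on the ring at this place would compare with compound 2 at 33700 nM.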